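Benzyl to pyridylmethyl swap on the shared core

The compounds below may be only part of what the source reports. "The series", "measured", "known", "first", "only" and "open" are said of these compounds alone.

The shared core is seen in compound 1 `O=c1c2ccccc2c(Nc2n[nH]c3ccccc23)nn1-c1ccccc1`, for which the entry in a functional assay on COLO 205 cells (Homo sapiens) for cytotoxicity (a lower number here means a stronger inhibitor, a higher number a weaker inhibitor), reads "not determined" (no result reported). Among the measured compounds shown here, compound 2 `Cc1cc(Nc2nn(Cc3cc(F)ccc3F)c(=O)c3ccccc23)n[nH]1` gives the only plain number in this assay, 3800 nM. Compound 3 `CC(=O)Nc1ccc(Cn2nc(Nc3cc(C)[nH]n3)c3ccccc3c2=O)cc1` reaches only a limit in this assay, > 30000 nM, which is the limit of > 30000 nM in this assay, at which 1 of the 3 values shown sits. Compound 4 `Cc1cc(Nc2nn(Cc3cccnc3)c(=O)c3ccccc23)n[nH]1` differs from compound 2 as follows: pyridin-3-yl in place of 2,5-difluorophenyl on a saturated chain carbon bound to an aromatic nitrogen. For the measured compounds named here, no step between measured compounds that differ in one place is available here, so the size of this change is untested; starting from compound 2 at 3800 nM, a small loss, close to the scatter, is expected rather than a large move. Compound 4 is estimated at 6000 nM, with a range from 2000 nM to 20000 nM. The expected step is a 1.6-fold higher number from compound 2 to compound 4 (0.20 log units; within the scatter).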

Compound 4, half-maximal inhibitory concentration: 4100 nM
The estimate for compound 4 lay 1.5-fold (0.17 log units) above the measured number, and the stated range covers the measured number.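

In this assay, among the compounds shown here, the step of a 1.1-fold higher number from compound 2 to compound 4 (0.03 log units; within the scatter) is the first that can be read at this position. On the saturated chain carbon bound to an aromatic nitrogen, pyridin-3-yl in place of 2,5-difluorophenyl therefore leaves the number within the scatter, even though the ring gains a hetero atom and loses both fluorines. No measured property shown bears on why this step is so small.

Still open, going by these compounds, is whether an amine, a carboxylic acid or a longer chain at this place would move the number beyond the scatter.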